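Sec-Butyl in Place of Isobutyl on the Amide Nitrogen Chain

The source may hold more compounds than are shown below. What is called first, only, known or untested is meant among the compounds shown, and "the series" means these compounds.

Measured compounds:
Compound 1 `CC1=C(O)[C@H](C/C(C)=C\CC[C@H](C)/C=C/C=C(\C)CCCC2=CCN(CCC(C)C)C2=O)OC1=O` gives 5 ug/mL in a functional assay on HCT-15 cells (Homo sapiens) for cytotoxicity; a higher number here means that more compound is needed for the effect, a lower number that less compound is needed.
Compound 2 `CC1=C(O)[C@@H](C/C(C)=C\CC[C@H](C)/C=C/C=C(\C)CCCC2=CCN(CCC(C)C)C2=O)OC1=O` gives 3.8 ug/mL in this assay.

Compound 1 and compound 2 have the same atoms and bonds and differ only in configuration as drawn; their two values lie within the usual scatter of each other, the step of a 1.3-fold lower number from compound 1 to compound 2 (0.12 log units; within the scatter) being too small to count, which is consistent with the fact that compounds 1 and 2 differ only in the configuration as drawn.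

Compound 3 `CCC(C)CN1CC=C(CCC/C(C)=C/C=C/[C@@H](C)CC/C=C(/C)C[C@@H]2OC(=O)C(C)=C2O)C1=O` is not yet measured. It differs from compound 1 by sec-butyl in place of isobutyl on a saturated chain carbon bound to an amide-type nitrogen in a ring. Going by the values given here, no measured step touches this part of the molecule: the only step at hand, a 1.3-fold lower number from compound 1 to compound 2 (0.12 log units; within the scatter), concerns a ring stereocentre and was within the scatter. Nothing in the two measured compounds therefore points to a move in either direction in this assay, and no step beyond the scatter is expected.

For compound 3 in this assay the estimated value is 5 ug/mL, with a range from 2 ug/mL to 12 ug/mL, corresponding to an expected step of no change at the digits printed from compound 1 to compound 3 (within the scatter).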

Compound 3, concentration for half-maximal effect: 5.3 ug/mL
The estimate for compound 3 lay 1.1-fold (0.03 log units) below the measured number; the range from low to high includes it.
By their numbers in this assay, from the lowest: compounds 2, 1 and 3 (each within the scatter of the next).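

Sec-butyl in place of isobutyl on a saturated chain carbon bound to an amide-type nitrogen in a ring is the first change at this position with a measured result in this assay, and it gives a 1.1-fold higher number from compound 1 to compound 3 (0.03 log units; within the scatter). The two groups have the same atoms joined differently, so this position accepts this one rearrangement of the chain without a step that can be read. Nothing available bears on why the number holds here.

Going by these compounds, whether the same holds for a group of another kind remains open: a longer chain, a cyclohexyl ring, or an amine or carboxylic acid at the end of the chain could each give a different result. A single rearrangement also cannot show how far this position tolerates change in general.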